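The source may report more compounds than this note shows. Statements on the series, on what has been measured and on what is new or still open speak of the compounds shown alone.

Compound 1 `O=C(CN1CN(c2ccccc2)C2(CCN(C(=O)c3ccc(C4CCCCC4)cc3)CC2)C1=O)N1CCC(CO)CC1` gives the lowest number of the three measured here: in an assay on HEK293 cells for displacement of a labelled ligand from NPC1-like intracellular cholesterol transporter 1 (Homo sapiens) (a higher number here means a weaker inhibitor, a lower number a stronger inhibitor), compound 1 gives 1100 nM. Compound 2 `CC(C)(C)OC(=O)NC1CCCN(C(=O)CN2CN(c3ccccc3)C3(CCN(C(=O)c4ccc(C(C)(C)C)cc4)CC3)C2=O)C1` gives 4200 nM and compound 3 `CC(C)(C)OC(=O)NC1CCN(C(=O)CN2CN(c3ccccc3)C3(CCN(C(=O)c4ccc(C5CCCCC5)cc4)CC3)C2=O)CC1` gives 4800 nM in this assay. The unmeasured compound 4 `CS(=O)(=O)N1CCN(C(=O)CN2CN(c3ccccc3)C3(CCN(C(=O)c4ccc(C5CCCCC5)cc4)CC3)C2=O)CC1` differs from compound 1 at the amide carbonyl: 4-(methylsulfonyl)piperazin-1-yl in place of 4-(hydroxymethyl)piperidin-1-yl on a carbonyl carbon. Among the measured compounds shown here, only one measured step bears on this change, a 4.4-fold higher number from compound 1 to compound 3 (0.64 log units; beyond the scatter), where the hydroxymethyl on the saturated ring carbon gave way to a larger group and the number rose. Compound 4 likewise gives up the hydroxymethyl, so a modest rise, beyond the scatter, is expected, though its new group is smaller than that of compound 3; compound 4 is therefore estimated at 2500 nM, between 1000 nM and 6500 nM, a step of a 2.3-fold higher number from compound 1 to compound 4 (0.36 log units; beyond the scatter).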

Compound 4, half-maximal inhibitory concentration: 6300 nM
Compound 4: the middle estimate sits 2.5-fold (0.40 log units) below what was measured; the range from low to high includes it.
By their numbers in this assay, from the lowest: compound 1; then compounds 2, 3 and 4 (each within the scatter of the next).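

A second, quite different group on the carbonyl carbon also gives up ground: 4-(methylsulfonyl)piperazin-1-yl brings a 5.7-fold higher number from compound 1 to compound 4 (0.76 log units; beyond the scatter). The rise from 4-(hydroxymethyl)piperidin-1-yl therefore does not depend on a (tert-butoxycarbonyl)amino group, and among the compounds that differ only here, compound 1 keeps the lowest number. Nothing measured here explains the rise. The compounds shown leave open whether the hydroxymethyl itself matters, or whether a plain piperidin-1-yl, a 4-aminopiperidin-1-yl or a 4-(2-hydroxyethyl)piperidin-1-yl would stay as low as compound 1.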